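The compounds below may be only part of what the source reports. "The series", "measured", "known", "first", "only" and "open" are said of these compounds alone.

Compound 1 `O=C1/C(=C/c2ccncc2)CN(S(=O)(=O)c2ccc(Cl)cc2)C/C1=C\c1ccccc1F` and compound 2 `O=C1/C(=C/c2ccncc2)CN(S(=O)(=O)c2ccc(Br)cc2)C/C1=C\c1ccccc1F` share one core; compound 3 `O=C1/C(=C/c2cccnc2)CN(S(=O)(=O)c2ccc(Cl)cc2)C/C1=C\c1ccccc1C(F)(F)F` carries another, and the difference between the two cores is not broken down here. In a functional assay on SMMC-7721 cells (Homo sapiens) for cytotoxicity, read by MTT assay, with a stated time of 24 h (a lower number here means a stronger inhibitor, a higher number a weaker inhibitor), compound 1 gives 9600 nM and compound 2 gives 12600 nM. Compound 3 gives 4880 nM in this assay, the lowest of the three numbers, though its gap to compound 1 lies within the scatter and only its gap to compound 2 lies beyond it.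

The change from compound 1 to compound 2 is bromo in place of chloro on an aromatic carbon; it made a 1.3-fold higher number from compound 1 to compound 2 (0.12 log units; within the scatter), a step too small to read as a real difference.

Compound 4 `O=C1/C(=C/c2cccnc2)CN(S(=O)(=O)c2ccc(Br)cc2)C/C1=C\c1ccccc1C(F)(F)F`, not yet measured in this assay, arises from compound 3 by the same change, at the same place: bromo in place of chloro on an aromatic carbon. Among the compounds with values here, the expectation for compound 4 rests on the single earlier case of this change, which made a 1.3-fold higher number from compound 1 to compound 2 (0.12 log units; within the scatter), so a step of similar size and direction is expected here, with wide bounds because a 1.3-fold higher number from compound 1 to compound 2 (0.12 log units; within the scatter) is the only precedent.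

Compound 4 is therefore expected to give 6300 nM in this assay, with an expected step of a 1.3-fold higher number from compound 3 to compound 4 (0.11 log units; within the scatter), and a range from 3500 nM to 11500 nM.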

Compound 4, half-maximal inhibitory concentration: 5760 nM
The estimate for compound 4 lay 1.1-fold (0.04 log units) above the measured number, within the range that was stated.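

In this assay, bromo in place of chloro on the aromatic carbon para to a large group gives a 1.2-fold higher number from compound 3 to compound 4 (0.07 log units; within the scatter), so this step cannot be read as a real difference. Set beside the only earlier case of the same change, the step looks the same on both cores: the same change on two cores in this assay, a 1.3-fold higher number (0.12 log units; within the scatter) from compound 1 to compound 2 and a 1.2-fold higher number (0.07 log units; within the scatter) from compound 3 to compound 4, 1.1-fold (0.05 log units) apart, within the scatter of two such steps

Within these four compounds, the exchange of 4-chlorophenyl for 4-bromophenyl can therefore be carried from one core to the other without a detectable shift in the cytotoxicity number, but this rests on two cores only, and it does not show that the two halogens are interchangeable on any other core or in any other assay.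

The compounds shown carry only chloro or bromo at this place, so it remains open whether an amine, a carboxylic acid or a longer chain there would move the number beyond the scatter. Also open, on these data alone, is whether a step of this size would hold on a third core.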